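Trifluoromethyl for bromo on compound 2

The compounds below may be only part of what the source reports. "The series", "measured", "known", "first", "only" and "open" are said of these compounds alone.

Compound 1 `O=C(NC1CCCCC1)Oc1ccc(Cl)cc1C(=O)Nc1ccc(Br)cc1`: > 50000 nM
Compound 2 `O=C(Nc1ccccc1)Oc1ccc(Cl)cc1C(=O)Nc1ccc(Br)cc1`: > 50000 nM

In an ADME assay on HepG2 cells (Homo sapiens) for cytotoxicity, read by MTT assay (a higher number here means a weaker inhibitor, a lower number a stronger inhibitor), compound 1 gives > 50000 nM, which is a limit and not a number. Compound 2 likewise gives only a limit, > 50000 nM. Both measured compounds share that ceiling: the limit of > 50000 nM in this assay, at which 2 of the 2 values shown sit. Among the measured compounds shown here, the one measured step, a step that the two limits leave unreadable from compound 1 to compound 2, therefore offers no size, and it concerns another part of the molecule.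

Compound 3 `O=C(Nc1ccccc1)Oc1ccc(Cl)cc1C(=O)Nc1ccc(C(F)(F)F)cc1` carries trifluoromethyl in place of bromo on an aromatic carbon. For the measured compounds named here, no measured step covers this change, so no step beyond the scatter is expected, and a further limit is likely in this assay. The expected step is a number no higher from compound 2 to compound 3 (the limit leaves the size open). Compound 3 is estimated at 50000 nM, within 25000 nM to 100000 nM.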

Compound 3, half-maximal inhibitory concentration: 9800 nM
Compound 3: the middle estimate sits 5.1-fold (0.71 log units) above what was measured, and the stated range ends above it.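

In this assay, the change from 4-bromophenyl to 4-(trifluoromethyl)phenyl gives an at least 5.1-fold lower number from compound 2 to compound 3 (0.70 log units; beyond the scatter), so this position responds measurably, which the earlier step, unreadable between two limits, could not show. Compound 3 is the only compound shown that gives a number and not a limit: the limit of > 50000 nM in this assay, at which 2 of the 3 values shown sit.

On these data alone, the full size of the step stays open, with compound 2 known only as a limit. Also open, as far as these compounds go, is whether a nitrile or an amine at this position would lower the number as well, and whether cyclohexyl in place of phenyl would keep the effect of trifluoromethyl.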